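The compounds below may be only part of what the source reports. "The series", "measured", "known", "first", "only" and "open" are said of these compounds alone.

Measured in a functional assay on ID8 cells (Mus musculus) for antiproliferative activity; a higher number here means a weaker inhibitor, a lower number a stronger inhibitor:
- compound 1 `O=C(Nc1ccc(O)c2c(=O)cc(-c3ccccc3Cl)oc12)c1ccc(Cl)cc1`: 5500 nM
- compound 2 `COc1ccc(C(=O)Nc2ccc(O)c3c(=O)cc(-c4ccccc4Cl)oc23)cc1`: 5000 nM
- compound 3 `CS(=O)(=O)Nc1ccc(O)c2c(=O)cc(-c3ccccc3Cl)oc12`: 16000 nM

Compound 3, at 16000 nM, carries the highest number of the three in this assay. The two amides sit together, with a 1.1-fold lower number from compound 1 to compound 2 (0.04 log units; within the scatter). Compound 3 lies apart from both.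

The next compound is compound 4 `O=c1cc(-c2ccccc2Cl)oc2c(NS(=O)(=O)c3ccccc3)ccc(O)c12`, which has phenyl in place of methyl on a sulfonyl sulfur.

Within the data shown here, two measured steps bear on this change. They are a 2.9-fold higher number from compound 1 to compound 3 (0.46 log units; beyond the scatter) and a 3.2-fold higher number from compound 2 to compound 3 (0.51 log units; beyond the scatter). Each replaces an aromatic carbonyl group on the nitrogen with methylsulfonyl and gives a modest rise in the number. Compound 4 keeps the sulfonyl link but brings an aromatic ring back onto it. Among the measured compounds shown here, no measured pair compares a sulfonyl link with a carbonyl link while the aromatic ring stays in place, so the reversal can only be partly assumed. A modest move toward the amides is therefore expected, no larger than those two steps.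

The expected step is a 2.3-fold lower number from compound 3 to compound 4 (0.36 log units; beyond the scatter), an estimate only.

For compound 4 the estimated value is 7000 nM, with an expected range of 3500 nM to 16000 nM.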

Compound 4, half-maximal inhibitory concentration: 9500 nM
Estimate against measurement, compound 4: 1.4-fold (0.13 log units) below, and the stated range covers the measured number.
By their numbers in this assay, from the lowest: compounds 2, 1, 4 and 3 (each within the scatter of the next, the first and the last beyond it).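

In this assay, phenyl in place of methyl on a sulfonyl sulfur gives a 1.7-fold lower number from compound 3 to compound 4 (0.23 log units; within the scatter), so at this position the added aromatic ring produces no change that can be told from repeat-measurement scatter. Phenylsulfonyl in place of (4-methoxyphenyl)carbonyl gives a 1.9-fold higher number from compound 2 to compound 4 (0.28 log units; within the scatter), and phenylsulfonyl in place of (4-chlorophenyl)carbonyl gives a 1.7-fold higher number from compound 1 to compound 4 (0.24 log units; within the scatter), so, unlike methylsulfonyl, phenylsulfonyl on this nitrogen cannot be separated from either amide, and compound 4 sits within the scatter of all three earlier compounds. No supporting data are available to explain these results.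

The compounds shown leave open whether a longer chain, such as n-butyl, on the sulfonyl sulfur would stay within the scatter of methyl and phenyl, and whether an amine or a carboxylic acid on the phenyl ring of the phenylsulfonyl group would move the number beyond it. They also leave open how an unsubstituted phenylcarbonyl group on the nitrogen would compare with phenylsulfonyl, a pair that would change only the link while the aromatic ring stays in place.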